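The compounds below may be only part of what the source reports. "The series", "measured", "known", "first", "only" and "open" are said of these compounds alone.

Compound 2 `COc1cc(N(Cc2nc3ccccc3[nH]2)C(=O)c2ccc(F)cc2)cc(OC)c1OC` was tested in a functional assay on PC-3 cells (Homo sapiens) for inhibition, read by MTT assay, with a stated time of 48 h (on this read-out lower numbers stand for stronger inhibition and higher numbers for weaker inhibition), where compound 2 gives 21900 nM. Among the measured compounds shown here, its only measured neighbour is compound 1 `COc1cc(N(Cc2nc3ccccc3[nH]2)S(=O)(=O)c2ccccc2)cc(OC)c1OC`, which in this assay gives 25500 nM; the two differ by a 1.2-fold lower number from compound 1 to compound 2 (0.07 log units; within the scatter), so the pair sits within the scatter of each other and neither can be placed above the other.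

Compound 3 `COc1cc(N(Cc2nc3ccccc3[nH]2)C(=O)c2ccc(C)cc2)cc(OC)c1OC` is not yet measured. It departs from compound 2 by methyl in place of fluoro on an aromatic carbon. For the measured compounds named here, no measured step touches this position: the single step from compound 1 to compound 2 swaps the whole group on the ring nitrogen and was within the scatter, so it offers no guide to the size or direction of exchanging one small substituent for another on the outer ring. On that basis compound 3 is expected to give 22000 nM, a range of 9000 nM to 55000 nM, which amounts to an expected step of a 1.0-fold higher number from compound 2 to compound 3 (0.00 log units; within the scatter) and thus nothing beyond the scatter.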

Compound 3, half-maximal inhibitory concentration: 42000 nM
Beside the measured number, compound 3's estimate is 1.9-fold (0.28 log units) below it; the range from low to high includes it.
By their numbers in this assay, from the lowest: compounds 2, 1 and 3 (each within the scatter of the next).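

At this position, on an aromatic carbon para to a large group, this assay now gives a first reading: methyl in place of fluoro yields a 1.9-fold higher number from compound 2 to compound 3 (0.28 log units; within the scatter) and thus does not separate the two groups. Replacing phenylsulfonyl with (4-methylphenyl)carbonyl on the ring nitrogen gives a 1.6-fold higher number from compound 1 to compound 3 (0.22 log units; within the scatter) and likewise leaves the pair unseparated, so compounds 1, 2 and 3 cannot be put in any order. No measured information is available to explain these numbers.

Going by these compounds, whether an amine, a carboxylic acid or a longer chain such as propyl at this carbon would give a step beyond the scatter remains open. Also open, on these data alone, is whether fluoro or methyl on the phenyl ring of the phenylsulfonyl group would read the same way.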